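Replacing the Thiophene of Compound 2 with an Ethynyl Group

This account rests on a few compounds, and the source may have more. Where it says the series, first, only, none or still open, it means among the compounds named here.

Measured so far:
compound 1 `O=c1[nH]/c(=N\OCCCc2cccc(I)c2)ccn1[C@@H]1O[C@H](COP(=O)(O)OP(=O)(O)OP(=O)(O)O)[C@@H](O)[C@H]1O`, 325 nM
compound 2 `O=c1[nH]/c(=N\OCCCc2ccsc2)ccn1[C@@H]1O[C@H](COP(=O)(O)OP(=O)(O)OP(=O)(O)O)[C@@H](O)[C@H]1O`, 103 nM

Compound 2 stands at the lowest of the two numbers in a functional assay on 1321-N1 cells for agonist activity at P2Y purinoceptor 2 (Homo sapiens), read by scintillation counting and inositol phosphate accumulation; on this read-out lower numbers stand for an effect already at smaller amounts and higher numbers for an effect only at larger amounts of compound; the nearest measured point is compound 1, a step of a 3.2-fold lower number from compound 1 to compound 2 (0.50 log units; beyond the scatter). Compound 3 `C#CCCCO/N=c1/ccn([C@@H]2O[C@H](COP(=O)(O)OP(=O)(O)OP(=O)(O)O)[C@@H](O)[C@H]2O)c(=O)[nH]1` differs from compound 2 by ethynyl in place of thiophen-3-yl on a saturated chain carbon, three bonds along the chain from an oxygen. Going by the values given here, only the step from compound 1 to compound 2 bears on this change, and it was modest, though it concerns the swap of one ring for another, not the loss of a ring. For compound 3 a step of a 2.9-fold higher number from compound 2 to compound 3 (0.46 log units; beyond the scatter) toward a higher number is expected, with wide uncertainty. Compound 3 is therefore estimated at 300 nM, between 80 nM and 1200 nM.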

Compound 3, half-maximal effective concentration: 168 nM
The estimate for compound 3 lay 1.8-fold (0.25 log units) above the measured number, and the stated range covers the measured number.
By their numbers in this assay, from the lowest: compounds 2, 3 and 1 (each within the scatter of the next, the first and the last beyond it).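

In this assay an aromatic ring at the end of the chain proves dispensable: ethynyl, which has no ring, gives a 1.6-fold higher number from compound 2 to compound 3 (0.21 log units; within the scatter) and a 1.9-fold lower number from compound 1 to compound 3 (0.29 log units; within the scatter). The earlier compounds shown here both carried a ring here, so they could not show that a ringless group stays within the scatter of both. Nothing available explains this result. As far as these compounds go, it remains open whether an amine or a carboxylic acid at this place would keep the number in this range. A longer chain ending in ethynyl, or a chain with no triple bond, is equally unresolved.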